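A few compounds are considered here, and "the series" means these few. Any claim that something is new, unique, unknown or untested is made for them only; others in the source may bear on it.

Working notes on the series. Compound 1 `C#Cc1nc2ccccc2[se]1` and compound 2 `Brc1nc2ccccc2[se]1` share one core; compound 3 `C#CCNC(=O)c1csc(C#C)n1` and compound 4 `C#CCNC(=O)c1csc(Br)n1` share another, and the difference between the two cores is not broken down here.

In a functional assay on NCI-H522 cells (Homo sapiens) for cytotoxicity, with a stated time of 3 days (a higher number here means a weaker inhibitor, a lower number a stronger inhibitor), compound 1 gives 2170 nM. Compound 2 reaches only a limit of the assay, giving > 40000 nM in this assay. The change from compound 1 to compound 2 is bromo in place of ethynyl on an aromatic carbon. The measured step is an at least 18-fold higher number from compound 1 to compound 2 (1.26 log units; beyond the scatter); its size is only a lower bound, since the value of compound 2 sits at the limit of > 40000 nM in this assay, at which 1 of the 3 values shown sits.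

In this assay compound 3 gives 2100 nM, which lies within the scatter of compound 1. The change from compound 3 to compound 4 is bromo in place of ethynyl on an aromatic carbon. This is the same kind of change as that from compound 1 to compound 2, but the surroundings differ: in compound 2 the bromo sits on a five-membered aromatic ring with 1 nitrogen and 1 selenium, part of a fused or bridged system of two rings, whereas in compound 4 it sits on a five-membered aromatic ring with 1 nitrogen and 1 sulfur, two ring bonds from the ring atom that bears a group of 6 heavy atoms.

In this assay the expected step is a 19-fold higher number from compound 3 to compound 4 (1.28 log units; beyond the scatter), resting on the single measured case of this change, an at least 18-fold higher number from compound 1 to compound 2 (1.26 log units; beyond the scatter). Compound 4 is accordingly expected to give about 40000 nM in this assay, with a range from 12000 nM to 120000 nM and a fair chance that only a limit is reported.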

Compound 4, half-maximal inhibitory concentration: > 40000 nM
Compound 4 was reported as a limit; the forecaster's own chance of this, stated with the estimate: 55%; the middle value lies on the limit itself.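

In this assay the change from ethynyl to bromo on the second core gives an at least 19-fold higher number from compound 3 to compound 4 (1.27 log units; beyond the scatter), so the large loss seen on the first core appears here too, with both steps beyond the scatter. This shows that the change goes the same way on both cores, but not that its size carries over exactly, and the comparison of size stays unresolved: the same change on two cores in this assay, an at least 18-fold higher number (1.26 log units; beyond the scatter) from compound 1 to compound 2 and an at least 19-fold higher number (1.27 log units; beyond the scatter) from compound 3 to compound 4; the limit leaves it open whether they differ
Compound 4 gives > 40000 nM, which is a limit of the assay and not a number, and two cores are too few to support a rule for other cores in the series: the limit of > 40000 nM in this assay, at which 2 of the 4 values shown sit.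

From the compounds shown here alone, it remains open whether ethynyl is specifically needed on this ring carbon or whether other groups would also keep the cytotoxicity, as only ethynyl and bromo are compared there; a nitrile, a methyl or an amine at that place would separate these readings. Also open, going by these compounds, is what the group of 6 heavy atoms contributes, as it is the same in compound 3 and compound 4, and a longer chain or a carboxylic acid in its place would address that.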